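The source may report more compounds than this note shows. Statements on the series, on what has been measured and on what is new or still open speak of the compounds shown alone.

Three compounds of one series share a sulfamate-bearing core and have been measured, and a fourth awaits measurement. Compound 1 is `NS(=O)(=O)Oc1ccc2c(c1)CN(C(=O)c1ccc(N3CCCCC3)cc1)CC2` and compound 3 is `NS(=O)(=O)Oc1ccc2c(c1)CN(C(=O)c1ccc(N3CCC(Cc4ccccc4)CC3)cc1)CC2`; the two differ in one place only, (benzyl in place of hydrogen on a saturated ring carbon). In an assay on HEK293 cells for inhibition of Steryl-sulfatase (Homo sapiens), tested at 1 uM (on this read-out higher numbers stand for a stronger effect at the one concentration tested and lower numbers for a weaker effect), compound 1 gives 38.3%, while compound 3 gives 81.3%, so this change made a step of a number 43 percentage points higher from compound 1 to compound 3 (beyond the scatter).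

Compound 2 is `NS(=O)(=O)Oc1ccc2c(c1)CN(C(=O)c1cccc(N3CCCCC3)c1)CC2`. It has the same atoms as compound 1, joined differently; the difference between the two cores is not broken down here. In this assay compound 2 gives 11.9%, the lowest of the three numbers, and its gap to compound 1 lies beyond the usual scatter.

Compound 4 is `NS(=O)(=O)Oc1ccc2c(c1)CN(C(=O)c1cccc(N3CCC(Cc4ccccc4)CC3)c1)CC2`, not yet measured. It stands to compound 2 as compound 3 stands to compound 1: the change is benzyl in place of hydrogen on a saturated ring carbon, the same change at the same kind of place. Among the measured compounds shown here, the only measured example of this change is the step of a number 43 percentage points higher from compound 1 to compound 3 (beyond the scatter) on the core of compound 1; whether the core of compound 2 answers in the same way is unknown, so the expectation carries a wide range. Because compound 2 starts from 11.9%, a step of similar direction is expected, giving an estimated a number 36.1 percentage points higher from compound 2 to compound 4 (beyond the scatter). In this assay compound 4 is therefore expected to give about 48%, most likely between 22% and 74%.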

Compound 4, a percentage reported as inhibition, at one concentration (the size of the read-out at that concentration, not a potency): 41.9%
For compound 4 the middle estimate is 6.1 percentage points above the measured one, and the stated range covers the measured number.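

In this assay, putting benzyl in place of hydrogen on a saturated ring carbon also raises the number on the core of compound 2, a step of a number 30 percentage points higher from compound 2 to compound 4 (beyond the scatter). Set beside the earlier example, the two steps point the same way and do not differ by more than repeated measurements would: the same change on two cores in this assay, a number 43 percentage points higher (beyond the scatter) from compound 1 to compound 3 and a number 30 percentage points higher (beyond the scatter) from compound 2 to compound 4, 13 percentage points apart, within the scatter of two such steps. This shows that the change carried over from the core of compound 1 to the core of compound 2 with a similar gain, but two cores are only two cases, so it does not show that the gain would hold on any other core in the series, and steps read at one concentration are not changes in potency.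

The compounds shown carry only hydrogen or benzyl at this ring carbon, which leaves open whether phenyl, phenylethyl or cyclohexylmethyl there would give a similar step, and whether a benzyl bearing a fluorine or a carboxylic acid would keep it. Also open, as far as these compounds go, is how these steps would look at other concentrations: each number here gives only the size of the effect at the one concentration tested.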